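Shortening the Aryl Ether Tail of Compound 1

A few compounds are considered here, and "the series" means these few. Any claim that something is new, unique, unknown or untested is made for them only; others in the source may bear on it.

Compound 1 `COc1ccc(OCCCCCN2CCCC(COC(=O)c3ccccc3N3C(=O)CC(C)C3=O)C2)cc1` was tested in an in vitro functional assay on HEK ts201 cells for antagonist activity at Neuronal acetylcholine receptor; alpha4/beta2 (Homo sapiens), read by fluorescence and calcium flux (a lower number here means a stronger inhibitor, a higher number a weaker inhibitor), where compound 1 gives 14500 nM. Compound 2 `COc1ccc(OCCCCCN2CCCC(COC(=O)c3ccccc3-c3ccccc3)C2)cc1` gives 14500 nM, and compound 3 `CC(C)N1CCCC(COC(=O)c2ccccc2N2C(=O)CC(Cc3ccccc3)C2=O)C1` gives 8910 nM. On these numbers compound 1 stands level with compound 2, the two together at the top of the three, and the gap to compound 3 stays within the scatter, so all three sit close together.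

Among the measured compounds shown here, the one measured step, no change at the digits printed from compound 1 to compound 2 (within the scatter), replaces a group on the aromatic ring that carries the ester and leaves the number where it was.

Compound 4 `CC1CC(=O)N(c2ccccc2C(=O)OCC2CCCN(CCCCOc3ccccc3)C2)C1=O` differs from compound 1 in another region: phenoxy in place of (4-methoxyphenoxy)methyl on a saturated chain carbon, four bonds along the chain from an amine nitrogen in a ring. For the measured compounds named here, no measured step touches this tail, so the single step on record gives no direct guide; it shows only that a change elsewhere did not move the number. Compound 3 differs from compound 1 in more than one place, so its value is at most a rough pointer, and it too lies within the scatter of compound 1.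

Compound 4 is therefore expected to stay near compound 1, with an expected step of no change at the digits printed from compound 1 to compound 4 (within the scatter). The estimate for compound 4 is 14500 nM, with a range from 6000 nM to 35000 nM.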

Compound 4, half-maximal inhibitory concentration: 1700 nM
Compound 4: the middle estimate sits 8.5-fold (0.93 log units) above what was measured, outside the stated range (below it).
By their numbers in this assay, from the lowest: compound 4; then compounds 3, 1 and 2 (each within the scatter of the next).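

The tail is a part of the molecule to which this assay responds: an 8.5-fold lower number from compound 1 to compound 4 (0.93 log units; beyond the scatter) comes with phenoxy in place of (4-methoxyphenoxy)methyl, on a saturated chain carbon, four bonds along the chain from an amine nitrogen in a ring. Among the compounds shown here, the only earlier step, showing no change at the digits printed from compound 1 to compound 2 (within the scatter) for a change in another region, left open whether any single change could move this number, and this one does so beyond the scatter. No measurement at hand bears on the cause of this shift.

The change shortens the chain and removes the methoxy group together, so the compounds shown cannot say which of the two matters; a butyl-linked 4-methoxyphenoxy tail or a pentyl-linked plain phenoxy tail would separate them. Also open, as far as these compounds go, are how far the trend runs with a still shorter chain, such as a propyl linker, whether a fluorine on the phenoxy ring is accepted, and whether the same shorter tail acts alike when the phenyl group of compound 2 stands in place of the 3-methyl-2,5-dioxopyrrolidin-1-yl group.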